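A few compounds are considered here, and "the series" means these few. Any claim that something is new, unique, unknown or untested is made for them only; others in the source may bear on it.

In an ADME assay on HepG2 cells (Homo sapiens) for cytotoxicity, read by MTT assay, with a stated time of 72 h (on this read-out higher numbers stand for lower toxicity in this test and lower numbers for higher toxicity in this test), compound 1 `CC1(c2ccc(-c3ccccc3C#N)cc2)CC(S(=O)(=O)c2ccc(F)cc2)=C(c2ccc(/C(N)=N\O)cc2)O1` gives 58300 nM, and compound 2 `CC1(c2ccccc2)CC(S(=O)(=O)c2ccc(F)cc2)=C(c2ccc(/C(N)=N\O)cc2)O1` gives 68300 nM. The step of a 1.2-fold higher number from compound 1 to compound 2 (0.07 log units; within the scatter) stays within the usual scatter. Compound 3 `CC1(c2ccc(-c3cccc([N+](=O)[O-])c3)cc2)CC(S(=O)(=O)c2ccc(F)cc2)=C(c2ccc(/C(N)=N\O)cc2)O1` reaches only a limit in this assay, namely > 50000 nM. The steps a step that the limit leaves unreadable from compound 1 to compound 3 and a step that the limit leaves unreadable from compound 2 to compound 3 are therefore of unreadable size, as the limit of > 50000 nM in this assay, at which 1 of the 3 values shown sits, shows. Compound 4 `Cc1ccc(-c2ccc(C3(C)CC(S(=O)(=O)c4ccc(F)cc4)=C(c4ccc(/C(N)=N\O)cc4)O3)cc2)cc1` differs from compound 3 by 4-methylphenyl in place of 3-nitrophenyl on an aromatic carbon. Every measured value here sits close to or at the limit, so the expected step that the limit leaves unreadable from compound 3 to compound 4 is one of no size beyond the scatter, and the estimate rests on the near-identical values of compound 1 and compound 2 together with the limit of compound 3. The estimate for compound 4 in this assay is 60000 nM, with a range from 30000 nM to 120000 nM.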

Compound 4, half-maximal cytotoxic concentration: 13700 nM
Beside the measured number, compound 4's estimate is 4.4-fold (0.64 log units) above it; measured number outside the range, below it.
By their numbers in this assay, from the lowest: compound 4; then compounds 1 and 2 (each within the scatter of the next).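

In this assay, the aromatic carbon para to a large group turns out to be able to shift the number: 4-methylphenyl gives a 5.0-fold lower number from compound 2 to compound 4 (0.70 log units; beyond the scatter) and a 4.3-fold lower number from compound 1 to compound 4 (0.63 log units; beyond the scatter), whereas 2-cyanophenyl, the group in compound 1, gave only a 1.2-fold higher number from compound 1 to compound 2 (0.07 log units; within the scatter). Against compound 3 the change reads an at least 3.6-fold lower number from compound 3 to compound 4 (0.56 log units; beyond the scatter), but compound 3 gives only a limit, so this size is a minimum: the limit of > 50000 nM in this assay, at which 1 of the 4 values shown sits.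

The compounds shown leave open whether the methyl of compound 4 is what matters. An amine or a carboxylic acid in its place could test this.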